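The compounds below may be only part of what the source reports. "The series", "measured", "known", "first", "only" and "open" are said of these compounds alone.

Three compounds have been measured in a functional assay on MKN-45 cells (Homo sapiens) for cytotoxicity, read by MTT assay, with a stated time of 72 h; a higher number here means a weaker inhibitor, a lower number a stronger inhibitor:

Compound 1, `COc1cc2c(Oc3ccc(NC(=O)c4cc(-c5ccc(F)cc5)ccn4)cc3F)ccnc2cc1OCCCN1CCCCC1`: 1240 nM
Compound 2, `COc1cc2c(Oc3ccc(NC(=O)c4cc(-c5ccc(C(F)(F)F)cc5)ccn4)cc3F)ccnc2cc1OCCCN1CCCCC1`: 870 nM
Compound 3, `COc1cc2c(Oc3ccc(NC(=O)c4cc(-c5ccc(C(F)(F)F)cc5)ccn4)cc3F)ccnc2cc1OCCCN1CCN(C)CC1`: 330 nM

Compound 2 stands second highest of the three numbers in this assay. Its nearest neighbour is compound 1, with a 1.4-fold lower number from compound 1 to compound 2 (0.15 log units; within the scatter); its furthest is compound 3, with a 2.6-fold lower number from compound 2 to compound 3 (0.42 log units; beyond the scatter).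

Compound 4, `COc1cc2c(Oc3ccc(NC(=O)c4cc(-c5ccccc5)ccn4)cc3F)ccnc2cc1OCCCN1CCCCC1`, differs from compound 2 in one place: hydrogen in place of trifluoromethyl on an aromatic carbon. Among the compounds with values here, the only measured step that bears on this position is the one from compound 1 to compound 2, where a trifluoromethyl replaced a fluoro and the number moved by a 1.4-fold lower number from compound 1 to compound 2 (0.15 log units; within the scatter), a shift within the scatter. The step from compound 2 to compound 3 touches a different part of the molecule and says nothing about this position. On that basis the step to compound 4 in this assay is expected to be small, if anything toward a slightly higher number, as a 1.3-fold higher number from compound 2 to compound 4 (0.10 log units; within the scatter). Compound 4 is therefore estimated at 1100 nM, with a range from 500 nM to 2500 nM.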

Compound 4, half-maximal inhibitory concentration: 270 nM
Compound 4: middle estimate off by 4.1-fold (0.61 log units), on the high side; the whole stated range lies above it.
By their numbers in this assay, from the lowest: compounds 4 and 3 (each within the scatter of the next); then compounds 2 and 1 (each within the scatter of the next).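

In this assay this position, on an aromatic carbon para to a large group, responds more than the exchange of fluoro for trifluoromethyl had suggested: going from 4-(trifluoromethyl)phenyl to phenyl lowers the number (a 3.2-fold lower number from compound 2 to compound 4 (0.51 log units; beyond the scatter)), and hydrogen in place of fluoro does the same (a 4.6-fold lower number from compound 1 to compound 4 (0.66 log units; beyond the scatter)). Both steps lie beyond the scatter, so fluoro and trifluoromethyl, which lie within the scatter of each other, both stand on the higher side of hydrogen among these compounds. Nothing available accounts for this difference.

On these data alone, whether an amine or a methoxy group at this position would read like hydrogen or like fluoro remains open. Also open, as far as these compounds go, is whether the plain phenyl and the 4-methylpiperazin-1-yl chain, which gave its own step (a 2.6-fold lower number from compound 2 to compound 3 (0.42 log units; beyond the scatter)), would add up in one molecule.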